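Swapping an aryl amide for a pyrazole in a cytotoxicity series

This account rests on a few compounds, and the source may have more. Where it says the series, first, only, none or still open, it means among the compounds named here.

Measured so far:
- compound 1, `Cc1ccccc1C(=O)Nc1ccc2nc(NC(=O)C3CCCCC3)sc2c1`: 0.085 ug/mL
- compound 2, `CCCC(C)C(=O)Nc1ccc2nc(NC(=O)C3CCCCC3)sc2c1`: 0.14 ug/mL

Both compounds were tested in a functional assay on WI-38 VA13 cells (Homo sapiens) for cytotoxicity; a lower number here means that less compound is needed, a higher number that more compound is needed for the effect. Compound 1 holds the lowest of the two numbers, and its nearest neighbour is compound 2, where the step of a 1.6-fold higher number from compound 1 to compound 2 (0.22 log units; within the scatter) stays within the scatter of repeated measurements. Within the data shown here, that single step, which replaces 2-methylphenyl with 1-methylbutyl on a carbonyl carbon, is the only comparison available, and it suggests that changing the group on this carbonyl carbon leaves the read-out largely unchanged.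

The unmeasured compound 3, `Cn1nccc1C(=O)Nc1ccc2nc(NC(=O)C3CCCCC3)sc2c1`, departs from compound 1 at the same carbonyl carbon: 1-methyl-1H-pyrazol-5-yl in place of 2-methylphenyl on a carbonyl carbon. The change bearing on it is the step from compound 1 to compound 2, which was small. Among the measured compounds shown here, no measured pair reports what a nitrogen-containing five-membered aromatic ring does in this position, so the expectation rests on the tolerance already seen. A step of about a 1.4-fold higher number from compound 1 to compound 3 (0.15 log units; within the scatter) is therefore expected, most likely within the scatter. Compound 3 is estimated at 0.12 ug/mL, with a range from 0.05 ug/mL to 0.35 ug/mL.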

Compound 3, half-maximal effective concentration: 0.58 ug/mL
Estimate against measurement, compound 3: 4.8-fold (0.68 log units) below; the measured number lies above the stated range.
By their numbers in this assay, from the lowest: compounds 1 and 2 (each within the scatter of the next); then compound 3.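

Placing 1-methyl-1H-pyrazol-5-yl on this carbonyl carbon gives a 6.8-fold higher number from compound 1 to compound 3 (0.83 log units; beyond the scatter) and a 4.1-fold higher number from compound 2 to compound 3 (0.62 log units; beyond the scatter) in this assay and so shows that the position does not treat every group alike. The earlier pair suggested broad tolerance, since an aromatic ring of carbon only and an open chain could not be told apart, yet this third group clearly requires more compound than either. Of the three groups, only 1-methyl-1H-pyrazol-5-yl has a five-membered ring, hetero atoms in its ring and hydrogen-bond acceptors, but these features all arrive together and no measurement here explains the shift.

The compounds shown therefore leave open whether the ring size, the ring nitrogens or the methyl on the pyrazole matters most, and a plain phenyl, a pyridine or a thiophene on the same carbonyl carbon would help to pull these apart. From the compounds shown here alone, it also remains open how this position would respond to a chain ending in an amine or a carboxylic acid.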